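A few compounds are considered here, and "the series" means these few. Any claim that something is new, unique, unknown or untested is made for them only; others in the source may bear on it.

In a functional assay on NCI-H1993 cells (Homo sapiens) for inhibition, read by CCK-8 assay, with a stated time of 72 h (on this read-out higher numbers stand for weaker inhibition and lower numbers for stronger inhibition), compound 1 `Cn1nccc1-c1cnc2ncn(Cc3ccc4ncccc4c3)c2n1` gives 7910 nM and compound 2 `c1cnc2ccc(Cn3cnc4ncc(-c5ccncc5)nc43)cc2c1` gives 1160 nM as the lower of the two numbers. Compound 3 `Fc1ccccc1-c1cnc2ncn(Cc3ccc4ncccc4c3)c2n1` has 2-fluorophenyl in place of pyridin-4-yl on an aromatic carbon. Going by the values given here, the one measured step at this place, the change to compound 2 (a 6.8-fold lower number from compound 1 to compound 2 (0.83 log units; beyond the scatter)), is modest but beyond the scatter. Among the compounds with values here, no compound with 2-fluorophenyl has been measured, so a step of similar or smaller size is expected in this assay towards a higher number. The expected change is a 2.4-fold higher number from compound 2 to compound 3 (0.38 log units; beyond the scatter) as an estimate. For compound 3 the estimated value is 2800 nM with an expected range from 700 nM to 9000 nM in this read-out.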

Compound 3, half-maximal inhibitory concentration: > 10000 nM
Compound 3: a limit, no number (the forecaster's own chance of this, stated with the estimate: 5%); at least 3.5-fold (0.55 log units) between middle value and limit.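

In this assay, compound 3 gives a limit and not a number: the limit of > 10000 nM in this assay, at which 1 of the 3 values shown sits. The change from pyridin-4-yl to 2-fluorophenyl gives an at least 8.6-fold higher number from compound 2 to compound 3 (0.93 log units; beyond the scatter), so this position does not keep the reading of compound 2 with this carbon-only aromatic ring. The change from 1-methyl-1H-pyrazol-5-yl gives an at least 1.2-fold higher number from compound 1 to compound 3 (0.10 log units; that floor lies within the scatter), which leaves these two unordered.

The compounds shown do not separate the loss of the ring nitrogen from the arrival of the fluorine. As far as these compounds go, how an unsubstituted phenyl or an amine at this carbon would read also stays open.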